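Extending the alkyl chain of compound 1

A few compounds are considered here, and "the series" means these few. Any claim that something is new, unique, unknown or untested is made for them only; others in the source may bear on it.

In a functional assay on cells (Lymphocyte, Homo sapiens), read by trypan blue exclusion, with a stated time of 16 h, tested at 2.5 uM (a lower number here means a weaker effect, a higher number a stronger effect of the compound at the concentration tested), compound 1 `CCCCCCCCCCCCCCCCc1c(C)c(N(C)C)nc(C)c1O` gives 85%, with compound 2 `CCCCCCCCCCc1nc(N(C)C)c(C)c(C)c1O` at 79% and compound 3 `CCCCCCCCCCCCCCCCc1c(C)c(N2CCC2)nc(C)c1O` at 92%, all three numbers within the scatter of one another. Compound 4 `CCCCCCCCCCCCCCCCCCCc1c(C)c(N(C)C)nc(C)c1O` differs from compound 1 by propyl in place of hydrogen on a saturated chain carbon, ten or more bonds along the chain from an aromatic carbon. Among the compounds with values here, no measured step touches the chain itself: the only step, azetidin-1-yl in place of dimethylamino on an aromatic carbon, gave a number 7 percentage points higher from compound 1 to compound 3 (within the scatter), and compound 2, which carries a shorter chain alongside other changes, shows no separation from compound 1 beyond the scatter. Compound 4 is therefore expected to stay near compound 1, with an estimated step of a number 1 percentage points lower from compound 1 to compound 4 (within the scatter). The estimate for compound 4 is 84%, between 70% and 95%.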

Compound 4, a percentage reported as activity, at one concentration (the size of the read-out at that concentration, not a potency): 87%
The estimate for compound 4 lay 3 percentage points below the measured number; the measured number falls inside the stated range.
By their numbers in this assay, from the lowest: compounds 2, 1, 4 and 3 (each within the scatter of the next, the first and the last beyond it).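

Within the data shown here, the first measured step on the chain itself is propyl in place of hydrogen on a saturated chain carbon, ten or more bonds along the chain from an aromatic carbon, and in this assay it gave a number 2 percentage points higher from compound 1 to compound 4 (within the scatter). This position therefore accepts the longer chain with no separation from compound 1 at the single concentration tested. Nothing available explains this result.

The compounds shown leave open whether an amine or a carboxylic acid in place of propyl at this position would keep the number. They also leave open how a shorter chain would read on the core of compound 1 with nothing else changed.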